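The source may hold more compounds than are shown below. What is called first, only, known or untested is meant among the compounds shown, and "the series" means these compounds.

The measured compounds:

Compound 1 `Cn1c(-c2ccccc2)cnc1NC(=O)c1cccc(Cl)c1`: in a toxicity assay on THP-1 cells (Homo sapiens) for inhibition (on this read-out higher numbers stand for lower toxicity in this test and lower numbers for higher toxicity in this test), compound 1 stops at the limit > 50000 nM, which is not a number.
Compound 2 `COc1ccc(-c2cn(C)c(NC(=O)c3ccc(F)cc3)n2)cc1`: in this assay compound 2 also stops at the limit > 50000 nM.
Compound 3 `COc1ccc(-c2cnc(NC(=O)c3ccc(F)cc3)n2-c2ccccc2)cc1`: in this assay compound 3 gives 8800 nM.

Compound 1 thus stands at a limit rather than a number, a limit shared with one other compound here (the limit of > 50000 nM in this assay, at which 2 of the 3 values shown sit). Compound 4 `Cn1c(-c2ccccc2)cnc1NC(=O)c1ccc(Cl)cc1` has not been measured yet. It differs from compound 1 in a single place (4-chlorophenyl in place of 3-chlorophenyl on a carbonyl carbon). Among the measured compounds shown here, no pair of measured compounds differing in one place is available, so no measured step sets the expected size. The step that the limit leaves unreadable from compound 1 to compound 4 is expected to be none beyond the usual scatter. Compound 4 is therefore estimated at about 60000 nM in this assay, with a range from 25000 nM to 150000 nM, and most likely again only a limit.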

Compound 4, half-maximal cytotoxic concentration: > 100000 nM
Compound 4 gave a limit, no number; the forecaster's own chance of this, stated with the estimate: 70%; middle value at least 1.6-fold (0.22 log units) away from the limit.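

Among the compounds shown here, compound 1 and compound 4 both stop at limits rather than numbers, so no step between them can be read. On these data alone, whether 4-chlorophenyl in place of 3-chlorophenyl changes the result in this assay at all stays open.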